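Phenyl in Place of Isopropyl: An Expected Step

This account rests on a few compounds, and the source may have more. Where it says the series, first, only, none or still open, it means among the compounds named here.

Of the compounds shown here, three have been measured in an assay on membranes from Jurkat cells for displacement of a labelled ligand from Sigma non-opioid intracellular receptor 1 (Homo sapiens), read by scintillation counting, with a stated time of 2 h; on this read-out lower numbers stand for stronger inhibition and higher numbers for weaker inhibition. Compound 1 `CC(C)c1ccc(-c2nc(CN3CCCC3)nn2C)cc1` gives 96 nM, the highest of the three numbers. Among the compounds with values here, compound 2 `Cn1nc(CN2CCCC2)nc1-c1cccc(C(C)(C)C)c1` gives 29 nM, and compound 3 `CC(C)(C)c1ccc(-c2nc(CN3CCCC3)nn2C2CC2)cc1` gives 14 nM; each of these lies beyond the usual scatter from compound 1, which therefore stands as the weakest of the three measured so far.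

Compound 4 `Cn1nc(CN2CCCC2)nc1-c1ccc(-c2ccccc2)cc1` has not yet been measured. It differs from compound 1 by phenyl in place of isopropyl on an aromatic carbon. Within the data shown here, no measured pair shows this particular change, so its effect is not known from the data. A step toward a lower number, of moderate size, is expected: a 2.1-fold lower number from compound 1 to compound 4 (0.33 log units; beyond the scatter). This expected step is roughly comparable to the gap seen between compound 1 and compound 2. Compound 4 is accordingly estimated at 45 nM, within a range from 15 nM to 140 nM.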

Compound 4, inhibition constant: 90 nM
Estimate against measurement, compound 4: 2.0-fold (0.30 log units) below; the range from low to high includes it.
By their numbers in this assay, from the lowest: compound 3; then compound 2; then compounds 4 and 1 (each within the scatter of the next).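

In this assay, within the data shown here, the first direct comparison at this position gives a 1.1-fold lower number from compound 1 to compound 4 (0.03 log units; within the scatter), so phenyl in place of isopropyl leaves the number effectively unchanged. On this aromatic carbon, para to a large group, the larger six-membered aromatic ring of carbon only is accommodated as readily as the smaller isopropyl. Nothing at hand bears on why the two groups read alike. Going by these compounds, whether an amine or a carboxylic acid at this place would also leave the number unchanged remains open. So does whether phenyl reads the same on the core of compound 3.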